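Methyl for cyclohexyl in the fluorophenyl amide series

This account rests on a few compounds, and the source may have more. Where it says the series, first, only, none or still open, it means among the compounds named here.

compound 1 (`Cc1nc(-c2ccc(F)cc2)c(C(=O)N2CCN(c3cccc(Cl)c3)CC2)o1`): 40.1 nM
compound 2 (`COc1ccc(-c2nc(C)oc2C(=O)N2CCN(c3cccc(Cl)c3)CC2)cc1`): "not active" (no number reported)
compound 3 (`O=C(c1oc(C2CCCCC2)nc1-c1ccccc1F)N1CCN(c2cccc(Cl)c2)CC1`): "not active" (no number reported)

In a functional assay on HL-60 cells (Homo sapiens) for inhibition, read by MTT assay, with a stated time of 72 h (on this read-out higher numbers stand for weaker inhibition and lower numbers for stronger inhibition), only compound 1 gives a number. Compound 3 has none and shares that standing with compound 2, so the two cannot be ranked against each other.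

Compound 4 (`Cc1nc(-c2ccccc2F)c(C(=O)N2CCN(c3cccc(Cl)c3)CC2)o1`) is the next to be measured. The structural change methyl in place of cyclohexyl on an aromatic carbon puts methyl in place of cyclohexyl on an aromatic carbon, next to the ring nitrogen and next to the ring oxygen. The 2-fluorophenyl group stays.

With no number for compound 3, no size can be put on this step. The expected direction is towards stronger inhibition. Compound 1 also carries methyl on that carbon and gives 40.1 nM in this assay (its aryl group also bears fluorine). Compound 2 goes against this, with methyl on that carbon and "not active" (no number reported) as its result, so a result without a number remains a real possibility for compound 4.

Compound 4 is estimated at 150 nM in this assay as the middle value, with 15 nM as the lower and 3000 nM as the upper end of the expected range.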

Compound 4, half-maximal inhibitory concentration: 39.4 nM
The estimate for compound 4 lay 3.8-fold (0.58 log units) above the measured number, and the stated range covers the measured number.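

In this assay compound 4 gives 39.4 nM, whereas compound 3 gives "not active" (no number reported), so methyl in place of cyclohexyl on this aromatic carbon goes with a measurable result while the 2-fluorophenyl group stays, though the step between the two cannot be read as a size. With methyl on that carbon, moving the fluorine gives a 1.0-fold lower number from compound 1 to compound 4 (0.01 log units; within the scatter), so 2-fluorophenyl and 4-fluorophenyl are not told apart in this assay. No measurement here bears on why these results fall as they do.

Open, as far as these compounds go, is how the result changes on this carbon between methyl and cyclohexyl, for example with ethyl, isopropyl or cyclopropyl, and whether cyclohexyl paired with a 4-fluorophenyl group also gives no number. Within the data shown here, also open is what an unsubstituted phenyl or a chlorophenyl group would give with methyl on that carbon, since only two fluorophenyl groups carry numbers so far.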